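Replacing an Open-Chain Amine by a Cyclic Amine

The source may report more compounds than this note shows. Statements on the series, on what has been measured and on what is new or still open speak of the compounds shown alone.

Measured compounds:
Compound 1, `CC(C(=O)NCc1ccc(C(F)(F)F)nc1NCc1ccccc1)c1ccc(NS(C)(=O)=O)c(F)c1`: 15.8 nM
Compound 2, `CCCCN(C)c1nc(C(F)(F)F)ccc1CNC(=O)C(C)c1ccc(NS(C)(=O)=O)c(F)c1`: 0.8 nM
Compound 3, `C[C@H](C(=O)NCc1ccc(C(F)(F)F)nc1N1CC[C@@H](N(C)C)C1)c1ccc(NS(C)(=O)=O)c(F)c1`: 101 nM

All three were characterised in a functional assay on CHO-K1 cells for antagonist activity at transient receptor potential cation channel subfamily V member 1 (Homo sapiens), read by FLIPR; on this read-out higher numbers stand for weaker inhibition and lower numbers for stronger inhibition. Compound 2 stands lowest of the three numbers shown; compound 1 is the nearest to it and compound 3 the furthest. Going by the values given here, the one step that can be counted, a 20-fold lower number from compound 1 to compound 2 (1.30 log units; beyond the scatter), exchanges benzylamino for butyl(methyl)amino on an aromatic carbon. Among the compounds with values here, compound 3 carries a cyclic amine bearing a dimethylamino substituent in the same place; no single step to it is counted, and its value set against that of compound 2 simply shows that this cyclic amine goes with a far higher number than the open chain.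

Compound 4, `CC(C(=O)NCc1ccc(C(F)(F)F)nc1N1CCC(CN(C)C)CC1)c1ccc(NS(C)(=O)=O)c(F)c1`, has not yet been measured. It differs from compound 2 in one place: 4-((dimethylamino)methyl)piperidin-1-yl in place of butyl(methyl)amino on an aromatic carbon. The counted step a 20-fold lower number from compound 1 to compound 2 (1.30 log units; beyond the scatter) bears on it only by showing that this position moves the number strongly. The pairing of compound 2 with compound 3 is the closer guide, since compound 3, at 101 nM, also carries a ring bearing dimethylamino in that place. A rise beyond the scatter is therefore expected, a 38-fold higher number from compound 2 to compound 4 (1.57 log units; beyond the scatter). Compound 4 is estimated at 30 nM, within 5 nM to 200 nM.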

Compound 4, inhibition constant: 2.1 nM
The estimate for compound 4 lay 14-fold (1.15 log units) above the measured number; the measured number lies below the stated range.
By their numbers in this assay, from the lowest: compound 2; then compound 4; then compound 1; then compound 3.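

The position on the aromatic carbon next to the ring nitrogen proved able to carry a cyclic amine with only a limited penalty: in this assay, placing 4-((dimethylamino)methyl)piperidin-1-yl there in place of butyl(methyl)amino gave a 2.6-fold higher number from compound 2 to compound 4 (0.42 log units; beyond the scatter). The same group also improved on benzylamino, with a 7.5-fold lower number from compound 1 to compound 4 (0.88 log units; beyond the scatter), so a six-membered non-aromatic ring with 1 hetero atom at this place can still give a number that stands below that of an open-chain amine. The far higher number of compound 3 therefore does not hold for every cyclic amine here, and the open chain of compound 2 keeps only a modest lead, though one beyond the scatter.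

The ring and its dimethylaminomethyl arm enter together, so the shown compounds do not separate their shares; a plain piperidine, a morpholine, or a carboxylic acid in place of the dimethylamino group would bear on that question. Nothing measured here accounts for why the number moves as it does at this position.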